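The compounds below may be only part of what the source reports. "The series", "measured", "known", "first", "only" and "open" are said of these compounds alone.

Measured so far in a functional assay on A549 cells (Homo sapiens) for antiproliferative activity, read by MTT assay, with a stated time of 24 h; a higher number here means a weaker inhibitor, a lower number a stronger inhibitor
compound 1 `O=C(NNc1ccccc1Cl)c1ccccc1NS(=O)(=O)c1cnc(O)nc1O` gives 5480 nM
compound 2 `O=C(NNc1cccc(Cl)c1)c1ccccc1NS(=O)(=O)c1cnc(O)nc1O` gives 5290 nM
compound 3 `O=C(NNc1ccccc1F)c1ccccc1NS(=O)(=O)c1cnc(O)nc1O` gives 9610 nM

Compound 3 cannot be ranked against the other two, since its value lies within the scatter of both. The steps are a 1.8-fold higher number from compound 1 to compound 3 (0.24 log units; within the scatter) and a 1.8-fold higher number from compound 2 to compound 3 (0.26 log units; within the scatter), and the remaining pair is no further apart, with a 1.0-fold lower number from compound 1 to compound 2 (0.02 log units; within the scatter) in this assay as well.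

The next compound is compound 4 `Cc1ccccc1C(=O)NNC(=O)c1ccccc1NS(=O)(=O)c1cnc(O)nc1O`, which has (2-methylphenyl)carbonyl in place of 2-fluorophenyl on an amine nitrogen. The measured steps only exchange one halogen-bearing phenyl for another. None brings in a carbonyl, so none measures this change directly. Resting only on the small size of a 1.8-fold higher number from compound 2 to compound 3 (0.26 log units; within the scatter), no step beyond the scatter is expected in this assay, and no direction is firmly expected. The estimate is a 1.4-fold lower number from compound 3 to compound 4 (0.14 log units; within the scatter), with wide uncertainty. The estimated value for compound 4 is 7000 nM (expected range 2500 nM to 20000 nM).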

Compound 4, half-maximal inhibitory concentration: 5450 nM
The estimate for compound 4 lay 1.3-fold (0.11 log units) above the measured number; low and high end bracket the measured number.
By their numbers in this assay, from the lowest: compounds 2, 4, 1 and 3 (each within the scatter of the next).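

Moving from a phenyl directly on the amine nitrogen to a carbonyl-linked one leaves the result in this assay within the scatter for all three pairs (a 1.8-fold lower number from compound 3 to compound 4 (0.25 log units; within the scatter); a 1.0-fold higher number from compound 2 to compound 4 (0.01 log units; within the scatter); a 1.0-fold lower number from compound 1 to compound 4 (0.00 log units; within the scatter)). The earlier compounds shown here varied only the halogen and its place on the phenyl, whereas this step shows that the position also accepts (2-methylphenyl)carbonyl, which brings in a hydrogen-bond acceptor and a double bond outside the ring, with no change beyond the scatter. No measurement at hand accounts for this.

It remains open whether the methyl on the new group matters, since an unsubstituted benzoyl is not among these compounds. Going by these compounds, it also remains open whether a carboxylic acid, an amine or a longer chain at this nitrogen would move the number beyond the scatter.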